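Will compound 3 leave the assay limit?

A few compounds are considered here, and "the series" means these few. Any claim that something is new, unique, unknown or untested is made for them only; others in the source may bear on it.

Compound 1 `COc1cc(CN(C(=O)CSc2nc3ccccc3s2)c2cc(OC)c(OC)c(OC)c2)cc(OC)c1OC`: > 80000 nM, a limit
Compound 2 `COc1cc(N(Cc2ccc(Cl)cc2)C(=O)CSc2nc3ccccc3s2)cc(OC)c1OC`: > 80000 nM, a limit

In a functional assay on PC-3 cells (Homo sapiens) for antiproliferative activity, read by MTT assay, with a stated time of 48 h (on this read-out higher numbers stand for weaker inhibition and lower numbers for stronger inhibition), compound 2 gives > 80000 nM, which is a limit and not a number. So far the series offers only (the limit of > 80000 nM in this assay, at which 2 of the 2 values shown sit).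

Compound 3 `COc1ccc(CN(C(=O)CSc2nc3ccccc3s2)c2cc(OC)c(OC)c(OC)c2)cc1C(F)(F)F` carries 4-methoxy-3-(trifluoromethyl)phenyl in place of 4-chlorophenyl on a saturated chain carbon bound to an amide-type nitrogen.

One measured step changed the group at this place, a step that the two limits leave unreadable from compound 1 to compound 2, and it gives no size to build on. With both ends of that step at a limit, no clear shift in this assay is expected, and a further limit is the likeliest result. For compound 3 the estimate is 80000 nM, with an expected range of 20000 nM to 150000 nM. The expected step is a number no higher from compound 2 to compound 3 (the limit leaves the size open).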

Compound 3, half-maximal inhibitory concentration: > 80000 nM
Compound 3 gave a limit, no number; the forecaster's own chance of this, stated with the estimate: 70%; the middle value lies on the limit itself.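

Compound 3 gave a limit and not a number, like compound 1 and compound 2, so no step among these three compounds can be read: the limit of > 80000 nM in this assay, at which 3 of the 3 values shown sit.

These compounds leave open whether any group at this place can give a measurable value, and how large such a step would be.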